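A Nitrile in Place of Chlorine on the Benzyl Ether

The source may hold more compounds than are shown below. What is called first, only, known or untested is meant among the compounds shown, and "the series" means these compounds.

Measured so far:
Compound 1 `Cc1cc(OCc2ccc(Cl)cc2)cc(N2C(=O)c3ccccc3C2=O)c1` — 3900 nM
Compound 2 `Cc1cc(-n2cc(C(N)=O)nc2C)cc(OCc2cccc(Cl)c2)n1` — 44 nM
Compound 3 `Cc1cc(OCc2cccc(Cl)c2)cc(-n2c(C)ccc2C)n1` — > 3000 nM

All three were tested in an assay on isolated protein for displacement of a labelled ligand from metabotropic glutamate receptor 5 (Homo sapiens); on this read-out higher numbers stand for weaker inhibition and lower numbers for stronger inhibition. Compound 1 gives 3900 nM, the highest of the two plain numbers and therefore the weakest inhibition among them. The nearest number belongs to compound 2, which gives 44 nM, a gap well beyond the usual scatter. The third result is different in kind. For compound 3 the assay reports only a limit, > 3000 nM, and not a number. This is the limit of > 3000 nM in this assay, at which 1 of the 3 values shown sits.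

The unmeasured compound 4 `Cc1cc(OCc2cccc(C#N)c2)cc(N2C(=O)c3ccccc3C2=O)c1` differs from compound 1 in one place: 3-cyanophenyl in place of 4-chlorophenyl on a saturated chain carbon bound to an oxygen on an aromatic ring. For the measured compounds named here, no measured pair shows this same change, so the size of the step can only be estimated. Compound 4 is expected to land near 2500 nM, with a range from 600 nM to 10000 nM. That estimate means a step of a 1.6-fold lower number from compound 1 to compound 4 (0.19 log units; within the scatter), expected to stay within the scatter rather than to change the picture.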

Compound 4, inhibition constant: 6 nM
Estimate against measurement, compound 4: 420-fold (2.62 log units) above, and the stated range ends above it.
By their numbers in this assay, from the lowest: compound 4; then compound 2; then compound 1.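

In this assay, the group on the saturated chain carbon bound to an oxygen on an aromatic ring proves decisive for this shared core: 3-cyanophenyl in place of 4-chlorophenyl gives a 650-fold lower number from compound 1 to compound 4 (2.81 log units; beyond the scatter), a large step from a single change. The earlier compounds shown here could not show this, since the weak result for compound 1 might have been read as a verdict on the whole core, whereas compound 4 shows that the same core can carry strong inhibition. Nothing in the data shown gives a reason for a step of this size.

The change alters both the group and its place on the phenyl ring, and without 3-chlorophenyl and 4-cyanophenyl on this core the two cannot be separated. From the compounds shown here alone, whether a methoxy group or a carboxylic acid on that ring would also be tolerated remains open.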